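The compounds below may be only part of what the source reports. "The series", "measured", "known", "first", "only" and "open" are said of these compounds alone.

Compound 1 `COC(=O)c1ccc(NCc2cncn2Cc2ccc(-c3ccccc3)cc2)cc1-c1ccccc1` carries the shared core. In a toxicity assay on NIH3T3 cells (Mus musculus) for cytotoxicity, read by resazurin assay (a lower number here means that less compound is needed, a higher number that more compound is needed for the effect), compound 1 reaches only a limit of the assay, giving > 1000 nM. Compound 2 `c1ccc(-c2ccc(Cn3cncc3CNc3ccc(-c4ccccc4)c(-c4ccccc4)c3)cc2)cc1` carries phenyl in place of methoxycarbonyl on an aromatic carbon. In this assay compound 2 likewise stops at a limit, giving > 10000 nM. Compound 3 `c1ccc(-c2ccc(Cn3cncc3CNc3ccc(N4CCCCC4)c(-c4ccccc4)c3)cc2)cc1` carries piperidin-1-yl in place of methoxycarbonyl on an aromatic carbon. In this assay compound 3 sits at a limit, giving > 1000 nM. The steps a step that the two limits leave unreadable from compound 1 to compound 2, a step that the two limits leave unreadable from compound 1 to compound 3 and a step that the two limits leave unreadable from compound 2 to compound 3 therefore have no readable size, because two of the three values sit at the limit of > 1000 nM in this assay, at which 2 of the 3 values shown sit, and the third at the limit of > 10000 nM in this assay, at which 1 of the 3 values shown sits. Compound 4 `c1ccc(-c2ccc(Cn3cncc3CNc3ccc(N4CCCC4)c(-c4ccccc4)c3)cc2)cc1` differs from compound 3 by pyrrolidin-1-yl in place of piperidin-1-yl on an aromatic carbon. Within the data shown here, no measured step shows this change, and all three measured steps leave their size unreadable, so no direction can be expected from them. Compound 4 is therefore expected in this assay to remain at a limit as well, with the estimated step that the limit leaves unreadable from compound 3 to compound 4 amounting to nothing readable. The estimate for compound 4 is 3000 nM, in a range from 1000 nM to 30000 nM.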

Compound 4, half-maximal effective concentration: > 1000 nM
Compound 4: a limit, no number; the forecaster's own chance of this, stated with the estimate: 85%; the middle value is on the limit's open side.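

In this assay compound 4 gives > 1000 nM, which is a limit and not a number. Its steps from compound 1, compound 2 and compound 3 cannot be read. The compounds shown leave open what concentration any of them needs for the effect in this assay.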